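The source may report more compounds than this note shows. Statements on the series, on what has been measured and on what is new or still open speak of the compounds shown alone.

Of the compounds shown here, three built on one shared core have been tested in an assay on CHO cells for displacement of a labelled ligand from adenosine receptor A3 (Homo sapiens), with a stated time of 60 min; on this read-out higher numbers stand for weaker inhibition and lower numbers for stronger inhibition. Compound 1 `CCCCC#Cc1nc(NCc2cccc(Br)c2)c2ncn([C@H]3[C@H](O)[C@H](O)[C@@H]4C[C@@H]43)c2n1` gives 8.6 nM. Compound 2 `CCCCC#Cc1nc(NCc2cccc(I)c2)c2ncn([C@H]3[C@H](O)[C@H](O)[C@@H]4C[C@@H]43)c2n1` gives 12 nM; the step of a 1.4-fold higher number from compound 1 to compound 2 (0.14 log units; within the scatter) comes from iodo in place of bromo on an aromatic carbon. Compound 3 `CCCCC#Cc1nc(NCC)c2ncn([C@H]3[C@H](O)[C@H](O)[C@@H]4C[C@@H]43)c2n1` gives 6.7 nM. On these numbers compound 3 stands lowest of the three, yet the steps of a 1.3-fold lower number from compound 1 to compound 3 (0.11 log units; within the scatter) and a 1.8-fold lower number from compound 2 to compound 3 (0.25 log units; within the scatter) both lie within the usual scatter, so no real ordering among the three can be claimed.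

Compound 4 `CCCCC#Cc1nc(NC2CC2)c2ncn([C@H]3[C@H](O)[C@H](O)[C@@H]4C[C@@H]43)c2n1` has not yet been measured. It differs from compound 3 in one place: cyclopropyl in place of ethyl on a nitrogen on an aromatic ring. The measured steps that bear on this are those that changed the group on the same nitrogen, namely the steps from compound 1 and compound 2 to compound 3, and each of them was small and within the scatter. Going by the values given here, no measured step trades ethyl for cyclopropyl directly, so the expectation rests on that neighbourhood alone. The step of a 1.0-fold lower number from compound 3 to compound 4 (0.01 log units; within the scatter) is therefore expected to be small, with no change beyond the scatter in either direction. For compound 4 in this assay the estimate is 6.5 nM, with a likely range from 2.5 nM to 18 nM.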

Compound 4, inhibition constant: 9.2 nM
The estimate for compound 4 lay 1.4-fold (0.15 log units) below the measured number; low and high end bracket the measured number.
By their numbers in this assay, from the lowest: compounds 3, 1, 4 and 2 (each within the scatter of the next).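

Going by these compounds alone, compound 4 puts a ring directly on this nitrogen for the first time, and in this assay trading ethyl for cyclopropyl gives a 1.4-fold higher number from compound 3 to compound 4 (0.14 log units; within the scatter), so on this core the new ring shifts the number by no more than repeat measurements would. The comparison with the larger groups reads the same way, with a 1.1-fold higher number from compound 1 to compound 4 (0.03 log units; within the scatter) and a 1.3-fold lower number from compound 2 to compound 4 (0.12 log units; within the scatter), so all four groups now seen on this nitrogen, from ethyl and cyclopropyl to 3-bromobenzyl and 3-iodobenzyl, fall within the scatter of one another and no ranking among them can be claimed. No measurement is available that could explain why these different groups give such similar numbers.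

Going by these compounds, it remains open whether any group on this nitrogen can move the number beyond the scatter, for example a longer chain such as hexyl, a larger ring such as cyclohexyl, or a chain carrying a carboxylic acid or an amine. These compounds also leave open whether cyclopropyl and ethyl would still read alike on a core with a different chain in place of the hexynyl group.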